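Swapping the amine tail on two fluoro-oxindole isomers

The source may hold more compounds than are shown below. What is called first, only, known or untested is meant among the compounds shown, and "the series" means these compounds.

Measured compounds:
compound 1, `CN(C)CCn1c(=O)c(=Cc2ccc(F)c(F)c2)s/c1=C1\C(=O)Nc2cc(F)ccc21`: 12100 nM
compound 2, `CCN(CC)CCCn1c(=O)c(=Cc2ccc(F)c(F)c2)s/c1=C1\C(=O)Nc2cc(F)ccc21`: 28 nM
compound 3, `CCN(CC)CCCn1c(=O)c(=Cc2ccc(F)c(F)c2)s/c1=C1\C(=O)Nc2ccc(F)cc21`: 640 nM

The study reports three compounds in a functional assay on HT-29 cells (Homo sapiens) for inhibition, read by MTT assay, with a stated time of 72 h; a higher number here means a weaker inhibitor, a lower number a stronger inhibitor. Compound 2 gives 28 nM, the lowest number of the three. Compound 1 differs from compound 2 by dimethylamino in place of (diethylamino)methyl on a saturated chain carbon, two bonds along the chain from an aromatic nitrogen, and in this assay compound 1 gives 12100 nM; the step is a 430-fold higher number from compound 2 to compound 1 (2.64 log units; beyond the scatter). Compound 3 shares the atoms of compound 2 joined differently; the difference between the two cores is not broken down here. In this assay compound 3 gives 640 nM, which stands between the other two.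

Compound 4, `CN(C)CCn1c(=O)c(=Cc2ccc(F)c(F)c2)s/c1=C1\C(=O)Nc2ccc(F)cc21`, has not been measured. For the measured compounds named here, it differs from compound 3 by dimethylamino in place of (diethylamino)methyl on a saturated chain carbon, two bonds along the chain from an aromatic nitrogen, the same change as the one from compound 2 to compound 1, at the same place. Among the compounds shown, this change occurs twice, and the one measured instance is the large step of a 430-fold higher number from compound 2 to compound 1 (2.64 log units; beyond the scatter). From the compounds shown here alone, whether the step carries over onto the core of compound 3 is unknown; it rests on a single pair. The account therefore expects the step from compound 3 to compound 4 to be a 130-fold higher number from compound 3 to compound 4 (2.10 log units; beyond the scatter), large because of a 430-fold higher number from compound 2 to compound 1 (2.64 log units; beyond the scatter) but with wide uncertainty. Compound 4 is estimated at 80000 nM, with a range from 8000 nM to 300000 nM, and it may be that only a limit is reported.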

Compound 4, half-maximal inhibitory concentration: 3090 nM
Beside the measured number, compound 4's estimate is 26-fold (1.41 log units) above it; measured number outside the range, below it.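

In this assay the same tail change on the second core gives a 4.8-fold higher number from compound 3 to compound 4 (0.68 log units; beyond the scatter), so the number rises on both cores, but this step is modest where the earlier one was large. The direction of the change therefore carries from one core to the other in these two pairs, while its size does not, and the two steps clearly differ: the same change on two cores in this assay, a 430-fold higher number (2.64 log units; beyond the scatter) from compound 2 to compound 1 and a 4.8-fold higher number (0.68 log units; beyond the scatter) from compound 3 to compound 4, 90-fold (1.95 log units) apart, beyond the scatter of two such steps

For the compounds shown here, what this does not show is why the size depends on the core, or how the change would behave on any other core, since the account rests on only two pairs. Nor does it separate the two parts of the change. 3-(diethylamino)propyl and 2-(dimethylamino)ethyl differ both in the chain and in the groups on the amine nitrogen, and neither part can be credited with any share of either step.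

The compounds shown leave open how a 2-(diethylamino)ethyl or a 3-(dimethylamino)propyl tail would read on either core, which would pull those two parts apart. They also leave open whether a ring amine such as morpholine, or a longer chain, would follow the same direction on both cores.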